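Adding an Acetyl Group to a Hydroxy Chain

The source may report more compounds than this note shows. Statements on the series, on what has been measured and on what is new or still open speak of the compounds shown alone.

In a functional assay on HCT-116 cells (Homo sapiens) for inhibition, read by fluorescence, with a stated time of 48 h (a higher number here means a weaker inhibitor of growth, a lower number a stronger inhibitor of growth), compound 3 `O=C1c2ccccc2C(OCCCO)(c2ccc(Cl)cc2)N1Cc1ccccc1` gives 90000 nM. That value lies within the usual scatter of the other two measured compounds: compound 1 `CC(C)[C@H](N)C(=O)OCCCOC1(c2ccc(Cl)cc2)c2ccccc2C(=O)N1Cc1ccc(Cl)cc1` gives 60000 nM and compound 2 `N[C@H](C(=O)OCCCOC1(c2ccc(Cl)cc2)c2ccccc2C(=O)N1Cc1ccc(Cl)cc1)c1ccccc1` gives 45000 nM. The unmeasured compound 4 `CC(=O)OCCCOC1(c2ccc(Cl)cc2)c2ccccc2C(=O)N1Cc1ccccc1` is compound 3 with one change, acetyl in place of hydrogen on an oxygen on a saturated carbon, which reads as hydroxy to acetoxy.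

Among the measured compounds shown here, the only measured step, a 1.3-fold lower number from compound 1 to compound 2 (0.12 log units; within the scatter), stays within the scatter, but it alters a different group. Compound 1 and compound 2 are esters at that same oxygen, yet they also differ from compound 3 elsewhere, so no measurement isolates this change. With compound 1 at 60000 nM and compound 2 at 45000 nM, both within the scatter of compound 3, no shift beyond the scatter is expected in this assay, in either direction. The estimated step is a 1.3-fold lower number from compound 3 to compound 4 (0.11 log units; within the scatter). For compound 4 the expected value is 70000 nM, with an estimated range of 30000 nM to 150000 nM.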

Compound 4, concentration for 50% growth inhibition: 80000 nM
Compound 4: the middle estimate sits 1.1-fold (0.06 log units) below what was measured; the range from low to high includes it.
By their numbers in this assay, from the lowest: compounds 2, 1, 4 and 3 (each within the scatter of the next).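

Replacing the hydrogen of the hydroxy group with acetyl in this assay gives a 1.1-fold lower number from compound 3 to compound 4 (0.05 log units; within the scatter), so the number stays within the scatter. Among the compounds shown here, this is the first direct reading at this oxygen, since compound 1 and compound 2 also carry esters there but differ from compound 3 in more than one place; here, a free hydroxy group is not needed to keep the number where it stands. No measurement shown here accounts for this result.

From the compounds shown here alone, whether an amine or a carboxylic acid in place of the acetyl, or a longer chain on the same oxygen, would move the number beyond the scatter remains open. Also unresolved is how much the amino acid esters of compound 1 and compound 2 contribute on their own, apart from their other difference from compound 3.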